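Compound 2 to compound 3: a side-chain exchange

This account rests on a few compounds, and the source may have more. Where it says the series, first, only, none or still open, it means among the compounds named here.

Measured in a functional assay on A549 cells (Homo sapiens) for cytotoxicity, read by MTT assay, with a stated time of 24 h; on this read-out lower numbers stand for stronger inhibition and higher numbers for weaker inhibition:
- compound 1 `C[C@H]1O[C@]1(C)C(=O)C[C@@H]1[C@@]2(C)[C@@H](O)CCC(C)(C)[C@]2(O)CC[C@@]1(C)O`: > 10000 nM
- compound 2 `C[C@H]1O[C@]1(C)C(=O)C[C@H]1[C@](C)(O)CC[C@@]2(O)C(C)(C)CCC[C@]12C`: > 10000 nM

For compound 2, > 10000 nM is a limit and not a number. Compound 3 `C/C=C(\C)C(=O)C[C@H]1[C@](C)(O)CC[C@@]2(O)C(C)(C)CCC[C@]12C` has 1-methylprop-1-en-1-yl in place of 2,3-dimethyloxiran-2-yl on a carbonyl carbon. For the measured compounds named here, the only measured step, a step that the two limits leave unreadable from compound 1 to compound 2, lies at another place and gives no size to carry over. All that bears on the change is the limit of > 10000 nM in this assay, at which 2 of the 2 values shown sit. Weak activity is therefore expected to persist, and the estimated step, a step that the limit leaves unreadable from compound 2 to compound 3, has no firm direction. Compound 3 is estimated at 15000 nM, with an expected range of 5000 nM to 50000 nM.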

Compound 3, half-maximal inhibitory concentration: > 10000 nM
Compound 3: a limit, no number; the forecaster's own chance of this, stated with the estimate: 75%; the middle value does not contradict the limit.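

Compound 2 and compound 3 both read as limits, not numbers, so no step can be read between them. The compounds shown leave open whether exchanging 2,3-dimethyloxiran-2-yl for 1-methylprop-1-en-1-yl changes cytotoxicity at all.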